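Acetyl in Place of Methylsulfonyl: Compound 3 to Compound 4

A few compounds are considered here, and "the series" means these few. Any claim that something is new, unique, unknown or untested is made for them only; others in the source may bear on it.

Of the compounds shown here, three have been measured in an assay on cells for displacement of a labelled ligand from prostaglandin E2 receptor EP4 subtype (Homo sapiens), read by scintillation counting; on this read-out lower numbers stand for stronger inhibition and higher numbers for weaker inhibition. Compound 1 `Cc1oc(CCC(=O)O)cc1COc1ccc(-c2ccccc2)cc1` gives 80 nM. Compound 2 `COc1ccc(-c2ccc(OCc3cc(C(=O)O)oc3C)cc2)cc1OC` gives 2800 nM. Going by the values given here, for compound 3 `Cc1oc(C(=O)O)cc1COc1ccc(-c2ccc(S(C)(=O)=O)cc2)cc1` the result is only a limit of the assay, > 10000 nM, and it is the single value among the three that sits at the limit of > 10000 nM in this assay, at which 1 of the 3 values shown sits. Compound 3 therefore stands at the weak end of what has been seen so far, without a number of its own, while compounds 1 and 2 both sit at numbered values.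

Compound 4 `CC(=O)c1ccc(-c2ccc(OCc3cc(C(=O)O)oc3C)cc2)cc1` differs from compound 3 in one place: acetyl in place of methylsulfonyl on an aromatic carbon. Among the compounds with values here, no step between measured compounds offers a direct guide to this exchange. The expectation is that compound 4 also lands near the weak end, with a step of an at least 1.2-fold lower number from compound 3 to compound 4 (0.09 log units; that floor lies within the scatter) that is estimated to bring the value just inside the numbered range rather than to shift it far. In this assay compound 4 is estimated at 8000 nM, with a range from 2000 nM to 30000 nM, and with a real chance that only a limit is reported once again.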

Compound 4, inhibition constant: 150 nM
Compound 4: middle estimate off by 53-fold (1.73 log units), on the high side; the whole stated range lies above it.
By their numbers in this assay, from the lowest: compounds 1 and 4 (each within the scatter of the next); then compound 2. At a limit, above all of these: compound 3.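

In this assay, acetyl in place of methylsulfonyl on an aromatic carbon, para to a large group, gives an at least 66-fold lower number from compound 3 to compound 4 (1.82 log units; beyond the scatter). Going by these compounds alone, this is the first comparison that changes a single place, and it shows that the group at this position can decide whether a compound reads as a number or only as a limit, even though the exchange removes just one heavy atom, one double bond outside aromatic rings and one hydrogen-bond acceptor. Compound 3 stands only at a limit, > 10000 nM, so the step gives a floor for the change and not its full size, because the value at that end has no number of its own: the limit of > 10000 nM in this assay, at which 1 of the 4 values shown sits.

Within the data shown here, the single exchange does not separate the effect of adding acetyl from that of removing methylsulfonyl, and it gives no cause for the change. It also leaves open whether an amide, a nitrile or a plain hydrogen at the same position would read nearer to compound 4 or to compound 3, and whether a longer chain there, such as propanoyl, would keep the number of compound 4.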